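Chain length from propyl to butyl on the amine side arm

A few compounds are considered here, and "the series" means these few. Any claim that something is new, unique, unknown or untested is made for them only; others in the source may bear on it.

Compound 3 `CN1CCN(CCCOc2c(OCc3ccccc3)cc3oc(-c4ccccc4)cc(=O)c3c2O)CC1` gives in a functional assay on A549 cells (Homo sapiens) for antiproliferative activity, read by MTT assay, with a stated time of 48 h (on this read-out lower numbers stand for stronger inhibition and higher numbers for weaker inhibition), the lowest number of the three measured, 1300 nM, yet its difference to compound 2 `O=c1cc(-c2ccccc2)oc2cc(OCc3ccccc3)c(OCCCN3CCCC3)c(O)c12`, which gives 1400 nM, is only a 1.1-fold lower number from compound 2 to compound 3 (0.03 log units; within the scatter). Compound 1 `O=c1cc(-c2ccccc2)oc2cc(OCc3ccccc3)c(OCCCN3CCCCC3)c(O)c12` gives 3100 nM; the steps from it are a 2.2-fold lower number from compound 1 to compound 2 (0.35 log units; beyond the scatter) and a 2.4-fold lower number from compound 1 to compound 3 (0.38 log units; beyond the scatter), both modest. Compound 4 `CN1CCN(CCCCOc2c(OCc3ccccc3)cc3oc(-c4ccccc4)cc(=O)c3c2O)CC1` carries (4-methylpiperazin-1-yl)methyl in place of 4-methylpiperazin-1-yl on a saturated chain carbon, three bonds along the chain from an oxygen on an aromatic ring; read one bond further out, this is 3-(4-methylpiperazin-1-yl)propyl to 4-(4-methylpiperazin-1-yl)butyl. All three measured steps concern only the amine ring, so none bears directly on a longer chain; they show that this end of the molecule tolerates change with at most modest movement. The expectation for compound 4 is therefore no step beyond the scatter, with a 1.1-fold higher number from compound 3 to compound 4 (0.03 log units; within the scatter). Compound 4 is estimated at 1400 nM, between 550 nM and 3600 nM.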

Compound 4, half-maximal inhibitory concentration: 4400 nM
The estimate for compound 4 lay 3.1-fold (0.50 log units) below the measured number; the measured number lies above the stated range.
By their numbers in this assay, from the lowest: compounds 3 and 2 (each within the scatter of the next); then compounds 1 and 4 (each within the scatter of the next).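

With the 4-methylpiperazin-1-yl ring held constant in this assay, going from 3-(4-methylpiperazin-1-yl)propyl to 4-(4-methylpiperazin-1-yl)butyl gives a 3.4-fold higher number from compound 3 to compound 4 (0.53 log units; beyond the scatter), so this side arm responds to chain length as well as to the amine ring. Against the pyrrolidin-1-yl propyl arm the butyl arm gives a 3.1-fold higher number from compound 2 to compound 4 (0.50 log units; beyond the scatter), while against the piperidin-1-yl propyl arm it gives a 1.4-fold higher number from compound 1 to compound 4 (0.15 log units; within the scatter), so the lengthened arm loses the step that separated the 4-methylpiperazin-1-yl propyl arm from the piperidin-1-yl propyl arm. No measurement bears on why the number rises with the longer chain.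

Still open, going by these compounds, is how a shorter 2-(4-methylpiperazin-1-yl)ethyl arm would read. Also open, on these data alone, is whether a butyl chain carrying pyrrolidin-1-yl or piperidin-1-yl moves the number as it does with 4-methylpiperazin-1-yl.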